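Methoxy in Place of Hydrogen Across a Series at the Limit

The compounds below may be only part of what the source reports. "The series", "measured", "known", "first", "only" and "open" are said of these compounds alone.

Compound 1 `COc1cc(OC)cc([C@@H]2/C(=C\c3ccccc3)c3cc(OC)cc(OC)c3[C@H]2c2ccccc2)c1` and compound 2 `COc1ccc(/C=C2/c3cc(OC)cc(OC)c3[C@@H](c3ccccc3)[C@@H]2c2cc(OC)cc(OC)c2)cc1` differ by methoxy in place of hydrogen on an aromatic carbon. In a functional assay on RAW264.7 cells (Mus musculus) for inhibition, with stated times of 2 h and 24 h (on this read-out lower numbers stand for stronger inhibition and higher numbers for weaker inhibition), compound 1 gives > 200000 nM, which is a limit of the assay and not a number. Compound 2 likewise gives > 200000 nM, again a limit. The step that the two limits leave unreadable from compound 1 to compound 2 is therefore unreadable in size. Compound 3 `COc1cc(OC)cc([C@@H]2C(SCc3ccccc3)c3cc(OC)cc(OC)c3[C@H]2c2ccccc2)c1` rests on another core; the difference between the core of compound 1 and that of compound 3 is not broken down here. In this assay compound 3 gives > 200000 nM, also a limit. Every value shown sits at the limit of > 200000 nM in this assay, at which 3 of the 3 values shown sit.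

Compound 4 `COc1ccc([C@@H]2c3c(OC)cc(OC)cc3C(SCc3ccccc3)[C@H]2c2cc(OC)cc(OC)c2)cc1` has not been measured. For the measured compounds named here, it differs from compound 3 by methoxy in place of hydrogen on an aromatic carbon, the same change as the one between compound 1 and compound 2, at a place described in the same words. Because the limit of > 200000 nM in this assay, at which 3 of the 3 values shown sit, holds all three values, and because a step that the two limits leave unreadable from compound 1 to compound 2 left the identical change unreadable, compound 4 is expected to give 200000 nM. The step of a number no higher from compound 3 to compound 4 (the limit leaves the size open) is itself expected to remain unreadable against the limit of this assay.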

Compound 4, half-maximal inhibitory concentration: > 200000 nM
Compound 4: a limit, no number; the forecaster's own chance of this, stated with the estimate: 85%; the middle value lies on the limit itself.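

In this assay compound 4 gives > 200000 nM, a limit and not a number. No step can be read from compound 3 to compound 4, and the values shown all sit at one point: the limit of > 200000 nM in this assay, at which 4 of the 4 values shown sit. The compounds shown leave open the size and direction of any effect of methoxy in place of hydrogen on inhibition.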